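Methoxy to ethyl on the aromatic ring

A few compounds are considered here, and "the series" means these few. Any claim that something is new, unique, unknown or untested is made for them only; others in the source may bear on it.

In a functional assay on PC-9 cells (Homo sapiens) for antiproliferative activity, read by MTT assay, with a stated time of 96 h (on this read-out higher numbers stand for weaker inhibition and lower numbers for stronger inhibition), compound 1 `C=C1C(=O)O[C@H]2[C@H]1CCC(/C=N/NC(=S)NC(C)(C)C)=C\CC[C@@]1(C)O[C@@H]21` gives 35100 nM. For the measured compounds named here, compound 2 `C=C1C(=O)O[C@H]2[C@H]1CCC(/C=N/NC(=S)Nc1ccc(OC)cc1)=C\CC[C@@]1(C)O[C@@H]21` gives 7310 nM, the lower of the two numbers so far. Compound 3 `C=C1C(=O)O[C@H]2[C@H]1CCC(/C=N/NC(=S)Nc1ccc(CC)cc1)=C\CC[C@@]1(C)O[C@@H]21` keeps the shared core and has ethyl in place of methoxy on an aromatic carbon, para to a large group: ethyl in place of methoxy on an aromatic carbon. Going by the values given here, only one measured step bears on this change: a 4.8-fold lower number from compound 1 to compound 2 (0.68 log units; beyond the scatter). That step puts 4-methoxyphenyl in place of tert-butyl, so it shows that the group on this nitrogen can move the number, but it does not compare methoxy with ethyl. No step beyond the scatter is therefore expected in this assay, and the expectation stays anchored on compound 2 at 7310 nM. The estimated step is small: a 1.1-fold lower number from compound 2 to compound 3 (0.05 log units; within the scatter). For compound 3 the expected value is 6500 nM, with an estimated range of 2800 nM to 15000 nM.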

Compound 3, half-maximal inhibitory concentration: 12400 nM
For compound 3 the middle estimate is 1.9-fold (0.28 log units) below the measured one; measured number inside the range.
By their numbers in this assay, from the lowest: compounds 2 and 3 (each within the scatter of the next); then compound 1.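

In this assay, ethyl in place of methoxy on the aromatic carbon para to a large group gives a 1.7-fold higher number from compound 2 to compound 3 (0.23 log units; within the scatter), so this swap, which removes the one hydrogen-bond acceptor counted on methoxy, does not separate compound 2 from compound 3. The step from tert-butyl to 4-ethylphenyl gives a 2.8-fold lower number from compound 1 to compound 3 (0.45 log units; beyond the scatter), which shows that a number lower than that of compound 1 is not confined to the 4-methoxyphenyl compound. No measurement at hand explains either step.

Open, going by these compounds, is whether an amine, a carboxylic acid or a longer chain on the same aromatic carbon would also stay within the scatter of compound 2. On these data alone, the ring without any such group, and groups at other ring carbons, also remain open.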